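A few compounds are considered here, and "the series" means these few. Any claim that something is new, unique, unknown or untested is made for them only; others in the source may bear on it.

Compound 3, with the structure `Oc1ccccc1/C=N/c1nnc(SCc2nnc(-c3ccc(Br)cc3)o2)s1`, gives 8320 nM in a functional assay on MCF7 cells (Homo sapiens) for inhibition, read by CCK-8 assay; a lower number here means a stronger inhibitor, a higher number a weaker inhibitor. Compound 1, `Oc1ccccc1/C=N/c1nnc(SCc2nnc(-c3ccccc3)o2)s1`, gives 9760 nM and compound 2, `Oc1ccccc1/C=N/c1nnc(SCc2nnc(-c3ccc(F)cc3)o2)s1`, gives 15600 nM; the steps of a 1.2-fold lower number from compound 1 to compound 3 (0.07 log units; within the scatter) and a 1.9-fold lower number from compound 2 to compound 3 (0.27 log units; within the scatter) both lie within the scatter, so the three compounds stand together rather than in any order. Compound 4, `Cc1ccccc1-c1nnc(CSc2nnc(/N=C/c3ccccc3O)s2)o1`, differs from compound 3 by 2-methylphenyl in place of 4-bromophenyl on an aromatic carbon. Among the measured compounds shown here, the only steps that bear on this are the exchanges on that phenyl ring, a 1.6-fold higher number from compound 1 to compound 2 (0.20 log units; within the scatter), a 1.2-fold lower number from compound 1 to compound 3 (0.07 log units; within the scatter) and a 1.9-fold lower number from compound 2 to compound 3 (0.27 log units; within the scatter), none of which moved beyond the scatter, so no step beyond the scatter is expected here either, a 1.1-fold higher number from compound 3 to compound 4 (0.06 log units; within the scatter). Compound 4 is therefore estimated at 9500 nM, between 4000 nM and 25000 nM.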

Compound 4, half-maximal inhibitory concentration: 9360 nM
Beside the measured number, compound 4's estimate is 1.0-fold (0.01 log units) above it, and the stated range covers the measured number.
By their numbers in this assay, from the lowest: compounds 3, 4, 1 and 2 (each within the scatter of the next).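

In this assay, the phenyl ring at this position now carries a methyl group in the 2-methylphenyl of compound 4 rather than a halogen or hydrogen, and all three new steps remain within the scatter (a 1.1-fold higher number from compound 3 to compound 4 (0.05 log units; within the scatter); a 1.7-fold lower number from compound 2 to compound 4 (0.22 log units; within the scatter); a 1.0-fold lower number from compound 1 to compound 4 (0.02 log units; within the scatter)). The four compounds thus show no separation among these phenyl groups, whether substituted as 4-fluorophenyl, 4-bromophenyl or 2-methylphenyl. No evidence is available to explain this result. The compounds shown leave open whether an amine, a carboxylic acid or a longer chain on that ring would produce a step beyond the scatter.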